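Replacing a biaryl tail with a stilbene tail on the acid core

The source may report more compounds than this note shows. Statements on the series, on what has been measured and on what is new or still open speak of the compounds shown alone.

Measured so far:
compound 1, `CCCCCCCCS(=O)(=O)Nc1cc(-c2ccc(CCCC)cc2)ccc1C(=O)O`, 15700 nM
compound 2, `CCCCCCCCS(=O)(=O)Nc1ccc(-c2ccc(CCCC)cc2)cc1C(=O)O`, 9000 nM
compound 3, `CCCCCCCCS(=O)(=O)Nc1cc(/C=C/c2ccccc2)ccc1C(=O)O`, 38000 nM

In an assay on mitochondria (strain BALB/c) for inhibition of glycerol-3-phosphate acyltransferase 1, mitochondrial (Mus musculus), read by scintillation counting, with a stated time of 10 min (on this read-out higher numbers stand for weaker inhibition and lower numbers for stronger inhibition), compound 2 gives 9000 nM, the lowest of the three numbers. Compound 1 sits closest, with a number within the scatter of that of compound 2, while compound 3 is clearly further off, beyond the scatter. Compound 4, `CCCCCCCCS(=O)(=O)Nc1ccc(/C=C/c2ccccc2)cc1C(=O)O`, has not yet been measured. It differs from compound 2 in one place: 2-phenylethenyl in place of 4-butylphenyl on an aromatic carbon.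

The same exchange is already seen once on the shared core, in the step from compound 1 to compound 3, which gave a 2.4-fold higher number from compound 1 to compound 3 (0.38 log units; beyond the scatter). Within the data shown here, that is the only measured step that bears on the present case, and it points to a modest weakening. Compound 4 is therefore expected to show a 2.3-fold higher number from compound 2 to compound 4 (0.37 log units; beyond the scatter) in this assay. The estimate for compound 4 is 21000 nM, with a range from 10000 nM to 45000 nM.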

Compound 4, half-maximal inhibitory concentration: 16300 nM
Estimate against measurement, compound 4: 1.3-fold (0.11 log units) above; low and high end bracket the measured number.
By their numbers in this assay, from the lowest: compounds 2, 1 and 4 (each within the scatter of the next); then compound 3.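

On the core of compound 2, the exchange of 4-butylphenyl for 2-phenylethenyl gives a 1.8-fold higher number from compound 2 to compound 4 (0.26 log units; within the scatter) in this assay, so at this place, meta to a carboxy group, the two tails cannot be told apart, whereas the same exchange on the core of compound 1 gave a step beyond the scatter. That contrast is not firm evidence that the two cores respond differently, as the gap between the two steps is itself within the scatter: the same change on two cores in this assay, a 2.4-fold higher number (0.38 log units; beyond the scatter) from compound 1 to compound 3 and a 1.8-fold higher number (0.26 log units; within the scatter) from compound 2 to compound 4, 1.3-fold (0.13 log units) apart, within the scatter of two such steps. The exchange can therefore be read as one modest step at most, and no separate effect of the core on it can be claimed.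

The compounds shown do not separate the double bond from the butyl chain, which a saturated 2-phenylethyl tail or a 4-butyl group on the 2-phenylethenyl ring could address. On these data alone, how an amine or a second carboxylic acid on the outer ring would read at this place also remains open.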